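Ethoxy for methoxy on two related benzothiophene-type cores

The source may report more compounds than this note shows. Statements on the series, on what has been measured and on what is new or still open speak of the compounds shown alone.

Compound 1 `COc1ccc(-c2c(C(=O)c3cc(OC)c(OC)c(OC)c3)sc3ccccc23)cc1` gives 4200 nM in a functional assay on HeLa cells (Homo sapiens) for antiproliferative activity, read by MTT assay, with a stated time of 72 h; a lower number here means a stronger inhibitor, a higher number a weaker inhibitor. Compound 2 `CCOc1ccc(-c2c(C(=O)c3cc(OC)c(OC)c(OC)c3)sc3ccccc23)cc1` gives 3000 nM. The change between them is methyl in place of hydrogen on a saturated chain carbon bound to an oxygen on an aromatic ring, and it made a 1.4-fold lower number from compound 1 to compound 2 (0.15 log units; within the scatter). Compound 3 `COc1ccc(Nc2c(C(=O)c3cc(OC)c(OC)c(OC)c3)sc3ccccc23)cc1` differs from compound 1 by (4-methoxyphenyl)amino in place of 4-methoxyphenyl on an aromatic carbon, and in this assay compound 3 gives 7700 nM, a step of a 1.8-fold higher number from compound 1 to compound 3 (0.26 log units; within the scatter); against compound 2 the step is a 2.6-fold higher number from compound 2 to compound 3 (0.41 log units; beyond the scatter). Compound 4 `CCOc1ccc(Nc2c(C(=O)c3cc(OC)c(OC)c(OC)c3)sc3ccccc23)cc1`, not yet measured, differs from compound 3 by methyl in place of hydrogen on a saturated chain carbon bound to an oxygen on an aromatic ring; the place is the same word for word as in the pair of compound 1 and compound 2, so this is the same change on the other core. For compound 4 the expected step is a 1.4-fold lower number from compound 3 to compound 4 (0.15 log units; within the scatter), resting on compound 1 and compound 2 with a 1.4-fold lower number from compound 1 to compound 2 (0.15 log units; within the scatter). Compound 4 is estimated at 5500 nM, between 3000 nM and 10000 nM.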

Compound 4, half-maximal inhibitory concentration: 700 nM
Estimate against measurement, compound 4: 7.9-fold (0.90 log units) above; the whole stated range lies above it.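

Methoxy to ethoxy gives an 11-fold lower number from compound 3 to compound 4 (1.04 log units; beyond the scatter) in this assay, so the size of this step did not carry from one core to the other: the same change on two cores in this assay, a 1.4-fold lower number (0.15 log units; within the scatter) from compound 1 to compound 2 and an 11-fold lower number (1.04 log units; beyond the scatter) from compound 3 to compound 4, 7.9-fold (0.90 log units) apart, beyond the scatter of two such steps. Replacing 4-ethoxyphenyl with (4-ethoxyphenyl)amino gives a 4.3-fold lower number from compound 2 to compound 4 (0.63 log units; beyond the scatter), and replacing 4-methoxyphenyl with (4-ethoxyphenyl)amino gives a 6.0-fold lower number from compound 1 to compound 4 (0.78 log units; beyond the scatter). These results show that the effect of this change depends on the core in these two pairs, but they do not explain that dependence or give a rule for predicting it on a further core.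

Open, as far as these compounds go, is whether activity on the core of compound 3 holds with a longer chain such as propoxy or butoxy. Also open, from the compounds shown here alone, is how a hydroxy group or an amine would compare with ethoxy at that place.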